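Second Methoxy Group on the Biaryl Boronic Amides

A few compounds are considered here, and "the series" means these few. Any claim that something is new, unique, unknown or untested is made for them only; others in the source may bear on it.

Compound 1 `O=C(CCc1cccc2c1B(O)OC2)Nc1ccccc1` is the simplest member of the set; in a functional assay on MDA-MB-231 cells (Homo sapiens) for antiproliferative activity, read by MTT assay, with a stated time of 72 h (on this read-out higher numbers stand for weaker inhibition and lower numbers for stronger inhibition), compound 1 gives 230 nM. Compound 2 `COc1ccc(NC(=O)CCc2cccc3c2B(O)OC3)cc1` carries methoxy in place of hydrogen on an aromatic carbon and in this assay compound 2 gives 850 nM, which amounts to a 3.7-fold higher number from compound 1 to compound 2 (0.57 log units; beyond the scatter). Compound 3 `COc1cccc(-c2cccc(NC(=O)CCc3cccc4c3COB4O)c2)c1` rests on a different core, and the difference between the two cores is not broken down here. In this assay compound 3 gives 76000 nM, the highest number of the three measured compounds. Compound 4 `COc1cc(OC)cc(-c2cccc(NC(=O)CCc3cccc4c3COB4O)c2)c1`, not yet measured, differs from compound 3 by methoxy in place of hydrogen on an aromatic carbon. Among the compounds with values here, this is the same kind of change as the one from compound 1 to compound 2, but the surroundings differ: in compound 2 the methoxy sits para to a large group, whereas in compound 4 it sits meta to a large group and meta to a methoxy group. In this assay compound 4 is expected to show a 1.6-fold higher number from compound 3 to compound 4 (0.20 log units; within the scatter), a step judged against the earlier one because compound 2 showed a 3.7-fold higher number from compound 1 to compound 2 (0.57 log units; beyond the scatter) and because compound 3 already stands at 76000 nM. Compound 4 is therefore estimated at 120000 nM, with a range from 40000 nM to 400000 nM.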

Compound 4, half-maximal inhibitory concentration: 93000 nM
Beside the measured number, compound 4's estimate is 1.3-fold (0.11 log units) above it, and the stated range covers the measured number.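

In this assay the second methoxy group gives a 1.2-fold higher number from compound 3 to compound 4 (0.09 log units; within the scatter), so on this core the change cannot be told apart from the scatter. Set beside the earlier step, the same change does not carry over in size from one core to the other: the same change on two cores in this assay, a 3.7-fold higher number (0.57 log units; beyond the scatter) from compound 1 to compound 2 and a 1.2-fold higher number (0.09 log units; within the scatter) from compound 3 to compound 4, 3.0-fold (0.48 log units) apart, beyond the scatter of two such steps. This comparison rests on a single pair on each core, and in compound 4 the new methoxy sits meta to a large group and meta to a methoxy group, so it does not show whether the core or the immediate surroundings of the group set the two steps apart, nor how the change would behave on any further core.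

Going by these compounds, it remains open whether other groups in place of the second methoxy, such as an amine, a hydroxyl or a fluorine, would also leave the number on this core within the scatter. Also open, on these data alone, is what a longer chain in place of the one carrying the amide would do to either step.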